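Replacing the 2-methylphenyl Amine Ring with a Pyridine

The source may report more compounds than this note shows. Statements on the series, on what has been measured and on what is new or still open speak of the compounds shown alone.

Of the compounds shown here, three have been measured: compound 1 `Cc1ccccc1Nc1nc2nonc2nc1Nc1ccccc1C` gives 2300 nM, compound 2 `Cc1ccccc1Nc1nc2nonc2nc1Nc1ccccc1F` gives 1100 nM, and compound 3 `Fc1ccccc1Nc1nc2nonc2nc1Nc1ccccc1OC(F)(F)F` gives 1700 nM in an assay on mitochondria from L6 cells (Rattus norvegicus) for activation, with a stated time of 90 min; a lower number here means that less compound is needed, a higher number that more compound is needed for the effect.

Compound 2 stands at the lowest of the three numbers; compound 3 sits within the scatter of it, and only compound 1 lies clearly apart, as a 2.1-fold lower number from compound 1 to compound 2 (0.32 log units; beyond the scatter) shows. Compound 4 `Fc1ccccc1Nc1nc2nonc2nc1Nc1ccccn1` differs from compound 2 in one place: pyridin-2-yl in place of 2-methylphenyl on a nitrogen on an aromatic ring. Among the compounds with values here, no measured step swaps one ring for another. The nearest comparisons exchange a group on a ring: a 2.1-fold lower number from compound 1 to compound 2 (0.32 log units; beyond the scatter) and a 1.5-fold higher number from compound 2 to compound 3 (0.19 log units; within the scatter), both small. On that basis a step within or just beyond the scatter is expected for compound 4, a 1.4-fold higher number from compound 2 to compound 4 (0.13 log units; within the scatter), giving an estimate of 1500 nM with a range of 500 nM to 5000 nM.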

Compound 4, half-maximal effective concentration: 9000 nM
For compound 4 the middle estimate is 6.0-fold (0.78 log units) below the measured one; measured number above the stated range.
By their numbers in this assay, from the lowest: compounds 2, 3 and 1 (each within the scatter of the next, the first and the last beyond it); then compound 4.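

Within the data shown here, exchanging 2-methylphenyl for pyridin-2-yl gives an 8.2-fold higher number from compound 2 to compound 4 (0.91 log units; beyond the scatter) in this assay and is the largest step so far, so this position responds more to replacing the ring than the earlier exchanges of a group on a ring suggested. The change removes the methyl and adds a ring nitrogen together, and the compounds shown cannot separate the two. No measurement here explains the step.

Going by these compounds, it remains open whether plain phenyl or pyridin-3-yl would give a number nearer that of compound 2 or that of compound 4.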